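A few compounds are considered here, and "the series" means these few. Any claim that something is new, unique, unknown or untested is made for them only; others in the source may bear on it.

Of the compounds shown here, three sharing one core have been tested in a functional assay on Ehrlich cells (Mus musculus) for cytotoxicity, tested at 25 ug/mL; on this read-out higher numbers stand for a stronger effect at the one concentration tested and lower numbers for a weaker effect. Compound 1 `COc1ccc(C2C(C#N)=C(N)N(c3cc(OC)c(OC)c(OC)c3)C3=C2C(=O)CC(C)(C)C3)cc1` gives 1%. Compound 2 `COc1cc(N2C(N)=C(C#N)C(/C=C/c3ccccc3)C3=C2CC(C)(C)CC3=O)cc(OC)c1OC` gives 30%. Compound 3 `COc1cc(N2C(N)=C(C#N)C(c3ccccc3O)C3=C2CC(C)(C)CC3=O)cc(OC)c1OC` gives 0%, the lowest of the three numbers, though its gap to compound 1 lies within the scatter; only compound 2 stands clearly apart, the step of a number 30 percentage points lower from compound 2 to compound 3 (beyond the scatter) marking that gap, while a number 1 percentage points lower from compound 1 to compound 3 (within the scatter) counts for nothing.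

The next compound, compound 4 `COc1cc(N2C(N)=C(C#N)C(c3c(O)ccc4ccccc34)C3=C2CC(C)(C)CC3=O)cc(OC)c1OC`, changes the group on the saturated ring carbon once more: 2-hydroxynaphthalen-1-yl in place of 2-hydroxyphenyl on a saturated ring carbon. Going by the values given here, no measured step replaces 2-hydroxyphenyl with a larger two-ring group, so the three steps give only indirect guidance. The 2-hydroxyphenyl compound sits at the bottom of the range, and the only clear move seen so far, a number 29 percentage points higher from compound 1 to compound 2 (beyond the scatter), came from a quite different group. A small upward step, possibly none beyond the scatter, is therefore expected in this assay, a number 8 percentage points higher from compound 3 to compound 4 (within the scatter). Compound 4 is estimated at 8%, within 0% to 30%.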

Compound 4, a percentage reported as activity, at one concentration (the size of the read-out at that concentration, not a potency): 10%
The estimate for compound 4 lay 2 percentage points below the measured number, within the range that was stated.
By their numbers in this assay, from the lowest: compounds 3, 1 and 4 (each within the scatter of the next); then compound 2.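

In this assay, replacing 2-hydroxyphenyl with 2-hydroxynaphthalen-1-yl on the saturated ring carbon adds a second aromatic ring, yet it gives a number 10 percentage points higher from compound 3 to compound 4 (within the scatter), so the larger group cannot be told apart from the smaller one on this read-out. Going by these compounds alone, the same holds against 4-methoxyphenyl, with a number 9 percentage points higher from compound 1 to compound 4 (within the scatter), while a number 20 percentage points lower from compound 2 to compound 4 (beyond the scatter) shows that 2-phenylethenyl is still the only group here that stands clearly apart from the others. Nothing available explains these numbers.

Going by these compounds, it remains open whether the 2-phenylethenyl result depends on its phenyl ring, which a plain propenyl chain or a cyclohexyl ring at this carbon would help to show. On these data alone, it is also open how a dimethylamino group or a carboxylic acid on the phenyl ring of 2-phenylethenyl would read here.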